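The compounds below may be only part of what the source reports. "The series", "measured", "known", "first", "only" and "open" are said of these compounds alone.

Compound 1 `Brc1cn2ccnc2c(-c2ccc3ncn(C4CCCCC4)c3c2)n1` is the starting point. Within the data shown here, in a functional assay on SF-268 cells (Homo sapiens) for inhibition, read by sulforhodamine B assay, with a stated time of 48 h, tested at 10 uM (a lower number here means less inhibition, a higher number more inhibition at the concentration tested (going by the name of the read-out)), compound 1 gives 17.1%, which is the top number of the two measured so far, though the gap to its only neighbour lies within the scatter. That neighbour, compound 2 `c1ccc2c(-c3cn4ccnc4c(-c4ccc5ncn(C6CCCCC6)c5c4)n3)cccc2c1`, gives 7.84% in this assay; the step of a number 9.3 percentage points lower from compound 1 to compound 2 (within the scatter) goes with naphthalen-1-yl in place of bromo on an aromatic carbon. Compound 3 `Fc1ccccc1-c1cn2ccnc2c(-c2ccc3ncn(C4CCCCC4)c3c2)n1` has not been measured. It differs from compound 1 thus: 2-fluorophenyl in place of bromo on an aromatic carbon. Among the measured compounds shown here, because the step of a number 9.3 percentage points lower from compound 1 to compound 2 (within the scatter) also put an aromatic ring in place of the same bromo and stayed within the scatter, it is the one step that bears on compound 3. No step beyond the scatter is therefore expected in this assay, which the estimated step of a number 4.1 percentage points lower from compound 1 to compound 3 (within the scatter) expresses. Compound 3 is expected to give 13%, with a range from 0% to 30%.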

Compound 3, a percentage reported as inhibition, at one concentration (the size of the read-out at that concentration, not a potency): 6.04%
The estimate for compound 3 lay 7 percentage points above the measured number, and the stated range covers the measured number.
By their numbers in this assay, from the lowest: compounds 3, 2 and 1 (each within the scatter of the next, the first and the last beyond it).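

Among these compounds, the change to 2-fluorophenyl in this assay gives a number 11.1 percentage points lower from compound 1 to compound 3 (beyond the scatter), the first step at this position that clears the scatter, so replacing bromo with an aromatic ring can be tied to a real, though modest, loss of inhibition. Swapping one aromatic group for the other gives a number 1.8 percentage points lower from compound 2 to compound 3 (within the scatter), so naphthalen-1-yl and 2-fluorophenyl cannot be told apart in this read-out, despite their difference in size. Nothing shown here gives a measured explanation for the difference between bromo and 2-fluorophenyl on this carbon.

The compounds shown leave open how an amine, a carboxylic acid or a short alkyl chain would read in place of bromo on this aromatic carbon. They also leave open whether a phenyl ring without fluorine would read like 2-fluorophenyl.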